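The compounds below may be only part of what the source reports. "The series", "measured", "known", "first", "only" and "open" are said of these compounds alone.

Measured so far:
- compound 1 `N#Cc1ccc(NCc2cncn2Cc2ccc(-c3ccccc3)cc2)cc1-c1ccccc1`: > 1000 nM
- compound 2 `CC(C)OC(=O)c1ccc(NCc2cncn2Cc2ccc(-c3ccccc3)cc2)cc1-c1ccccc1`: > 10000 nM

Both entries come from a toxicity assay on NIH3T3 cells (Mus musculus) for cytotoxicity, read by resazurin assay; a higher number here means that more compound is needed for the effect, a lower number that less compound is needed. Compound 2 gives > 10000 nM, which is a limit and not a number. Compound 1 gives > 1000 nM, which is also a limit. Within the data shown here, compound 2 therefore has no exact place on the scale, and the only other value shown gives no number to set it against.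

Compound 3 `CN(C)C(=O)c1ccc(NCc2cncn2Cc2ccc(-c3ccccc3)cc2)cc1-c1ccccc1` keeps the rest of compound 2 and carries dimethylamino in place of isopropoxy on a carbonyl carbon, so that isopropoxycarbonyl becomes dimethylcarbamoyl (dimethylamino in place of isopropoxy on a carbonyl carbon). Among the measured compounds shown here, the only measured step bearing on this is a step that the two limits leave unreadable from compound 1 to compound 2, with isopropoxycarbonyl in place of cyano on an aromatic carbon. That step offers no size to carry over, so no step beyond the scatter is expected in this assay, and no direction can be favoured. The expectation rests on compound 2, whose > 10000 nM is a limit.

The expected change is a number no higher from compound 2 to compound 3 (the limit leaves the size open). Compound 3 is estimated at 10000 nM, with an expected range from 2500 nM to 40000 nM.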

Compound 3, half-maximal effective concentration: > 1000 nM
Compound 3: a limit, no number (the forecaster's own chance of this, stated with the estimate: 75%); the middle value is on the limit's open side.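

In this assay compound 3 gives > 1000 nM, which is a limit and not a number. Among these compounds, compound 1, compound 2 and compound 3 all stand as limits, so no step among them can be read. The compounds shown leave open how much of each is needed for the effect, and whether exchanging cyano, isopropoxycarbonyl and dimethylcarbamoyl changes that amount at all.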